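The source may hold more compounds than are shown below. What is called first, only, known or untested is meant among the compounds shown, and "the series" means these compounds.

Measured in a functional assay on 786-0 cells (Homo sapiens) for antiproliferative activity, read by sulforhodamine B assay, with a stated time of 48 h; on this read-out lower numbers stand for stronger inhibition of growth and higher numbers for weaker inhibition of growth:
compound 1 `COc1ccc2cc(CO)oc(=O)c2c1` gives 37.6 ug/mL
compound 2 `COc1ccc2cc(CCCO)oc(=O)c2c1` gives 26.9 ug/mL
compound 3 `COc1ccc2c(c1)C(=O)OC(CO)C2` gives >= 250 ug/mL

The value of compound 3 is a limit of this assay, not a number. The difference between the core of compound 1 and the core of compound 3 is not broken down here. From compound 1 to compound 2 the change is 2-hydroxyethyl in place of hydroxy on a saturated chain carbon bound to an aromatic carbon; it made a 1.4-fold lower number from compound 1 to compound 2 (0.15 log units; within the scatter). Compound 4 `COc1ccc2c(c1)C(=O)OC(CCCO)C2` is not yet measured. It differs from compound 3 by 2-hydroxyethyl in place of hydroxy on a saturated chain carbon bound to a saturated ring carbon, the same kind of change, but here on a saturated chain carbon bound to a saturated ring carbon rather than on one bound to an aromatic carbon. In this assay a step of a number no higher from compound 3 to compound 4 (the limit leaves the size open) is expected because a 1.4-fold lower number from compound 1 to compound 2 (0.15 log units; within the scatter) and because compound 3 already sits at the limit of >= 250 ug/mL in this assay, at which 1 of the 3 values shown sits. Compound 4 is therefore expected near 250 ug/mL, between 120 ug/mL and 400 ug/mL.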

Compound 4, concentration for 50% growth inhibition: 102 ug/mL
Compound 4: the middle estimate sits 2.5-fold (0.39 log units) above what was measured, and the stated range ends above it.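

In this assay the change from hydroxymethyl to 3-hydroxypropyl, on a saturated chain carbon bound to a saturated ring carbon, gives an at least 2.4-fold lower number from compound 3 to compound 4 (0.38 log units; beyond the scatter). Compound 3 stands at a limit of the assay, not at a number: the limit of >= 250 ug/mL in this assay, at which 1 of the 4 values shown sits. The change therefore gives a step beyond the scatter on one core only, and carrying it to another core is neither shown to preserve its size nor shown to alter it: the same change on two cores in this assay, a 1.4-fold lower number (0.15 log units; within the scatter) from compound 1 to compound 2 and an at least 2.4-fold lower number (0.38 log units; beyond the scatter) from compound 3 to compound 4; the limit leaves it open whether they differ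

The compounds shown leave open what a longer chain would do on either core, or an amine or a carboxylic acid in place of the hydroxy. Also open, going by these compounds, is how much the difference between the two cores contributes by itself.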